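The source may report more compounds than this note shows. Statements on the series, on what has been measured and on what is new or still open speak of the compounds shown alone.

Working notes on the series. In an ADME assay on THP-1 cells (Homo sapiens) for cytotoxicity, read by MTT assay, with a stated time of 24 h (a lower number here means a stronger inhibitor, a higher number a weaker inhibitor), compound 1 `O=C(OCc1cn(-c2ccc(Cl)cc2)nn1)[C@@H]1CCCN1` gives 346000 nM and compound 2 `Cc1ccc(-n2cc(COC(=O)[C@@H]3CCCN3)nn2)cc1` gives 421000 nM as its reading. With only these two numbers available, compound 2 stands level with compound 1 within the scatter, and the two cannot be ranked.

Compound 3 `COc1ccc(-n2cc(COC(=O)[C@@H]3CCCN3)nn2)cc1` is still to be measured. Its difference from compound 2 is methoxy in place of methyl on an aromatic carbon and amounts to methoxy in place of methyl on an aromatic carbon, para to a large group.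

For the measured compounds named here, one measured step bears on this change: a 1.2-fold higher number from compound 1 to compound 2 (0.09 log units; within the scatter) with methyl in place of chloro on an aromatic carbon. That step lies within the scatter, so changing this substituent has not yet moved the number in this assay in a measurable way. Going by the values given here, a single step is thin support, and no measured compound carries methoxy. No direction is therefore expected, and the estimated 1.1-fold lower number from compound 2 to compound 3 (0.03 log units; within the scatter) stays within the scatter. For compound 3 the expected value is 390000 nM with an estimated range (210000 nM to 700000 nM) around it.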

Compound 3, half-maximal inhibitory concentration: 218000 nM
For compound 3 the middle estimate is 1.8-fold (0.25 log units) above the measured one; low and high end bracket the measured number.
By their numbers in this assay, from the lowest: compounds 3, 1 and 2 (each within the scatter of the next).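

With methoxy, this place on the aromatic ring, para to a large group, now carries three different substituents, and the first with an oxygen atom and a hydrogen-bond acceptor leaves this assay with a 1.9-fold lower number from compound 2 to compound 3 (0.29 log units; within the scatter) and with a 1.6-fold lower number from compound 1 to compound 3 (0.20 log units; within the scatter) as its two new steps. For the compounds shown here, both steps lie within the scatter, as did the earlier step from chloro to methyl, so methoxy, methyl and chloro cannot be ranked here, and adding the acceptor and one more heavy atom has produced no measurable step in this small set. No measurement is available that could explain these readings or say what the substituent does at this place.

On these data alone, it remains open whether a group of a different kind at this place, such as an amine, a carboxylic acid or a longer alkoxy chain, would give a step beyond the scatter, or whether this place has any measurable influence on the number at all. The three compounds also share everything outside this substituent, so they say nothing about how changes elsewhere in the shared core would read in this assay in this series.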